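Swapping pentyl for 2-methoxyethoxy on a long chain

This account rests on a few compounds, and the source may have more. Where it says the series, first, only, none or still open, it means among the compounds named here.

- Compound 1 (`CCCCCCCCCc1[nH]c2ccccc2c(=O)c1C`) reads 5.6 nM
- Compound 2 (`Cc1c(COc2cc(OCC3CCOCC3)ccn2)[nH]c2ccccc2c1=O`) reads 49 nM

In a functional assay on HUVEC cells (Homo sapiens) for inhibition, using NADPH, with a stated time of 2 h (on this read-out higher numbers stand for weaker inhibition and lower numbers for stronger inhibition), compound 1 holds the lower of the two numbers, and compound 2 lies above it by more than the scatter. Compound 3 (`COCCOCCCCc1[nH]c2ccccc2c(=O)c1C`), not yet measured, carries 2-methoxyethoxy in place of pentyl on a saturated chain carbon, four bonds along the chain from an aromatic carbon. Among the measured compounds shown here, no measured pair shows this change, so the expectation is loose: a step toward weaker inhibition, beyond the scatter. The expected size is a 7.1-fold higher number from compound 1 to compound 3 (0.85 log units; beyond the scatter) in this assay as an estimate only. Compound 3 is estimated at 40 nM (range 10 nM to 170 nM).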

Compound 3, half-maximal inhibitory concentration in the HUVEC assay: 460 nM
For compound 3 the middle estimate is 12-fold (1.06 log units) below the measured one, and the stated range ends below it.
By their numbers in the HUVEC assay, from the lowest: compound 1; then compound 2; then compound 3.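

In the HUVEC assay, compound 1 gives 5.6 nM and compound 3 gives 460 nM. In the HUVEC assay, 2-methoxyethoxy in place of pentyl on a saturated chain carbon, four bonds along the chain from an aromatic carbon, gives an 82-fold higher number from compound 1 to compound 3 (1.91 log units; beyond the scatter), so inhibition here depends strongly on what this end of the chain carries. In a physicochemical assay for solubility, at pH 6.8 (on this read-out higher numbers stand for higher solubility and lower numbers for lower solubility), the same change gives an at least 100-fold higher number from compound 1 to compound 3 (2.00 log units; beyond the scatter), and each end of that step is a limit of the assay. In the physicochemical assay compound 1 gives < 1000 nM, which is a limit of the assay. In the physicochemical assay compound 3 gives >= 100000 nM, which is also a limit of the assay. The compounds shown leave open whether a longer chain ending in 2-methoxyethoxy, or an amine on the same chain, would keep the reading of compound 1 in the HUVEC assay while approaching that of compound 3 in the physicochemical assay.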